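A few compounds are considered here, and "the series" means these few. Any claim that something is new, unique, unknown or untested is made for them only; others in the source may bear on it.

The measured compounds:

Compound 1, `Cc1ccc(-c2cn(C/C=C3\OC(=O)C(OCc4ccccc4)=C3OCc3ccccc3)nn2)cc1`, in a functional assay on CFPAC-1 cells (Homo sapiens) for antiproliferative activity, read by MTT assay, with a stated time of 72 h (on this read-out lower numbers stand for stronger inhibition and higher numbers for weaker inhibition), gives > 100000 nM, which is a limit of the assay and not a number.

Compound 2, `CCCCCc1ccc(-c2cn(C[C@H](O)[C@H]3OC(=O)C(OCc4ccccc4)=C3OCc3ccccc3)nn2)cc1`, in this assay gives 9890 nM.

Compound 3, `CC(C)(C)OC(=O)N1CCN(C(=S)SCc2cn(C[C@H](O)[C@H]3OC(=O)C(OCc4ccccc4)=C3OCc3ccccc3)nn2)CC1`, in this assay gives > 100000 nM, which again is a limit of the assay.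

Compound 1 therefore stands at the top of the range seen here, at the limit of > 100000 nM in this assay, at which 2 of the 3 values shown sit, and only compound 2 gives an actual number. Among the compounds with values here, no two measured compounds differ in a single place, so no measured step tells how a change on the aromatic carbon of the shared core is felt.

Compound 4, `COc1ccccc1-c1cn(C/C=C2\OC(=O)C(OCc3ccccc3)=C2OCc2ccccc2)nn1`, differs from compound 1 by 2-methoxyphenyl in place of 4-methylphenyl on an aromatic carbon. With compound 1 sitting at a limit, the step from compound 1 to compound 4 is expected to show no change beyond the scatter, and a number no higher from compound 1 to compound 4 (the limit leaves the size open) is the expected step, compound 4 most likely also being reported only as a limit. The estimate for compound 4 in this assay is 100000 nM, expected to lie between 25000 nM and 400000 nM.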

Compound 4, half-maximal inhibitory concentration: > 100000 nM
Compound 4: no number, only a limit; the forecaster's own chance of this, stated with the estimate: 70%; the middle value sits exactly at the limit.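

In this assay compound 4 gives > 100000 nM and this is a limit of the assay, not a number. Compound 1 also stands at a limit, and the step between compound 1 and compound 4 cannot be read. The compounds shown leave open whether 2-methoxyphenyl in place of 4-methylphenyl changes the activity at all.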